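A few compounds are considered here, and "the series" means these few. Any claim that something is new, unique, unknown or untested is made for them only; others in the source may bear on it.

Measured so far in a functional assay on HT-29 cells (Homo sapiens) for cytotoxicity, read by sulforhodamine B assay; a higher number here means a weaker inhibitor, a lower number a stronger inhibitor:
Compound 1, `C=C1[C@@H](C/C=C2/C(=O)OC[C@H]2OC(C)=O)[C@]2(C)CC[C@@H](OC(C)=O)[C@@](C)(CO[Si](C)(C)C(C)(C)C)[C@H]2C[C@@H]1O`: 9310 nM
Compound 2, `C=C1[C@@H](OC(C)=O)C[C@@H]2[C@](C)(CO[Si](C)(C)C(C)(C)C)[C@H](OC(C)=O)CC[C@@]2(C)[C@@H]1C[C@@H](Nc1ccccc1F)C1=CCOC1=O`: 3710 nM
Compound 3, `C=C1[C@@H](OC(C)=O)C[C@@H]2[C@](C)(COC=O)[C@H](OC(C)=O)CC[C@@]2(C)[C@@H]1C[C@@H](Nc1ccc(O)cc1)C1=CCOC1=O`: 13400 nM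

Compound 3 carries the highest number of the three. Against compound 1 the gap is within the scatter, so the two cannot be ranked; compound 2 sits beyond the scatter toward the stronger side. Compound 4, `C=C1[C@@H](OC(C)=O)C[C@@H]2[C@](C)(COC=O)[C@H](OC(C)=O)CC[C@@]2(C)[C@@H]1C[C@@H](Nc1ccc(C(=O)O)cc1)C1=CCOC1=O`, differs from compound 3 in one place: carboxy in place of hydroxy on an aromatic carbon. Going by the values given here, no pair of measured compounds shares this change, so nothing here shows its effect directly. The step from compound 3 to compound 4 is therefore expected to be small, a 1.1-fold higher number from compound 3 to compound 4 (0.05 log units; within the scatter), with no clear direction beyond the scatter. For compound 4 in this assay the estimate is 15000 nM, expected to fall between 5000 nM and 45000 nM.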

Compound 4, half-maximal inhibitory concentration: 37200 nM
Beside the measured number, compound 4's estimate is 2.5-fold (0.39 log units) below it; the range from low to high includes it.
By their numbers in this assay, from the lowest: compound 2; then compounds 1 and 3 (each within the scatter of the next); then compound 4.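

Read on its own, a 2.8-fold higher number from compound 3 to compound 4 (0.44 log units; beyond the scatter) in this assay, when carboxy replaces hydroxy on the aromatic carbon para to a large group. So what sits at this spot on the ring can move the number, and here carboxy gives the weaker inhibitor of the two. Nothing available explains why.

On these data alone, how a methyl ester or an amine at the same place would compare remains open. So does whether this change would have a similar effect on a compound that differs elsewhere.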